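The source may hold more compounds than are shown below. What is called first, only, known or untested is meant among the compounds shown, and "the series" means these compounds.

Compound 2 `CCN1CCN(c2cc(C)c3cc(NC(=O)c4cc(Cl)cc(Cl)c4)ccc3n2)CC1` gives 2660 nM in a functional assay on SK-BR-3 cells (Homo sapiens) for antiproliferative activity, read by MTT assay, with a stated time of 72 h (a lower number here means a stronger inhibitor, a higher number a weaker inhibitor), the lowest of the three numbers shown, though compound 1 `CCN(CC)CCNc1cc(C)c2cc(NC(=O)c3ccc(Cl)c(Cl)c3)ccc2n1` with 3710 nM lies within the scatter of it, while compound 3 `Cc1cc(N2CCCC2)nc2ccc(NC(=O)c3ccc(Cl)c(Cl)c3)cc12` with 43400 nM stands well beyond. The step of a 12-fold higher number from compound 1 to compound 3 (1.07 log units; beyond the scatter) concerns the amine side of the shared core and is the only measured step among these compounds. Compound 4 `CCN1CCN(c2cc(C)c3cc(NC(=O)c4ccc(C)cc4)ccc3n2)CC1` differs from compound 2 on the other side of the molecule: 4-methylphenyl in place of 3,5-dichlorophenyl on a carbonyl carbon. Going by the values given here, no measured step touches the aryl group on the carbonyl carbon, so nothing among the three measured compounds tells how far this change will move the number, or in which direction. What the two values of compound 1 and compound 2 show is that two dichlorophenyl patterns give numbers within the scatter of each other; a 4-methylphenyl is a different case entirely. Without a direct precedent the estimate must be cautious: compound 4 is expected to give a somewhat higher number, around 7000 nM, with a range from 2500 nM to 20000 nM, meaning an estimated step of a 2.6-fold higher number from compound 2 to compound 4 (0.42 log units; beyond the scatter).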

Compound 4, half-maximal inhibitory concentration: 11400 nM
Compound 4: middle estimate off by 1.6-fold (0.21 log units), on the low side; measured number inside the range.
By their numbers in this assay, from the lowest: compounds 2 and 1 (each within the scatter of the next); then compound 4; then compound 3.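

Going by these compounds alone, the step of a 4.3-fold higher number from compound 2 to compound 4 (0.63 log units; beyond the scatter) in this assay is the first measured change at the aryl group on the carbonyl carbon, and it shows that this side of the molecule also moves the number, with the amine side held fixed. Within the data shown here, until now, the only measured step, a 12-fold higher number from compound 1 to compound 3 (1.07 log units; beyond the scatter), lay on the amine side, so the result adds a second place where a single change goes beyond the scatter. No measurement shown accounts for the shift at this position.

Since both chlorines leave and a methyl enters in the same change, the compounds shown cannot separate their contributions, and a plain phenyl or a 4-chlorophenyl on the carbonyl carbon would bear on that. On these data alone, it also remains open whether the same change would give a similar step with the (2-(diethylamino)ethyl)amino group on the other side.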